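A few compounds are considered here, and "the series" means these few. Any claim that something is new, unique, unknown or untested is made for them only; others in the source may bear on it.

Three compounds have been measured in an ADME assay on RD cells (Homo sapiens) for cytotoxicity (a lower number here means that less compound is tolerated, a higher number that more compound is tolerated), and for each of them the assay reported only a limit:

compound 1, `Cc1ccccc1NC(=S)N/N=C1\C(=O)Nc2ccccc21`: > 25000 nM
compound 2, `COc1ccccc1NC(=S)N/N=C1\C(=O)Nc2ccccc21`: > 25000 nM
compound 3, `O=C1/C(=N\NC(=S)Nc2ccccc2)c2ccccc2N1Cc1ccccc1`: > 25000 nM

Compound 1 therefore stands at the limit of this assay, not at a measured number. The same holds for compound 2 and for compound 3, so nothing can be said about the order of the three; all that is shown is the limit of > 25000 nM in this assay, at which 3 of the 3 values shown sit.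

The step toward the unmeasured compound 4, `CCNC(=S)N/N=C1\C(=O)Nc2ccccc21`, is ethyl in place of 2-methylphenyl on an amide-type nitrogen. Within the data shown here, the only measured step that changes one place, a step that the two limits leave unreadable from compound 1 to compound 2, concerns a group on an aromatic carbon rather than this nitrogen, and its size is hidden by the two limits. Among the measured compounds shown here, no measured step therefore bears directly on the change to compound 4, and none of the three values gives a direction.

Compound 4 is expected to behave like the measured compounds, which means a step of a number no higher from compound 1 to compound 4 (the limit leaves the size open) and an estimate of 25000 nM, between 10000 nM and 60000 nM, with a good chance that this assay again reports only its limit.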

Compound 4, half-maximal cytotoxic concentration: > 25000 nM
Compound 4: a limit, no number; the forecaster's own chance of this, stated with the estimate: 80%; the middle value sits exactly at the limit.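

In this assay, among these compounds, compound 4 gives > 25000 nM, which is a limit and not a number, so no step from compound 1 to compound 4 can be read. The compounds shown leave open what actual number any of them would give, and whether any change among them matters, since all that is seen is this: the limit of > 25000 nM in this assay, at which 4 of the 4 values shown sit.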